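A Larger Oxygen-Bound Group on the Shared Core

The source may hold more compounds than are shown below. What is called first, only, known or untested is meant among the compounds shown, and "the series" means these compounds.

Of the compounds shown here, three with a shared core have been measured in an in vivo ADME assay on the whole organism (strain Sprague-Dawley) for pharmacokinetics, with Rattus norvegicus as the target; on this read-out lower numbers stand for lower oral bioavailability and higher numbers for higher oral bioavailability. Compound 1 `N=C(N)c1ccc2[nH]c(-c3cccc(-c4cc(F)ccc4O)c3O)cc2c1` gives a result that is only a limit of the assay, < 1%. Compound 2 `N/C(=N/O)c1ccc2[nH]c(-c3cccc(-c4ccccc4O)c3O)cc2c1` gives 15%. Compound 3 `C=CCO/N=C(/N)c1ccc2[nH]c(-c3cccc(-c4ccccc4O)c3O)cc2c1` gives 100%, the highest of the two numbers shown, with compound 2 as the nearest measured neighbour. Within the data shown here, the step of a number 85 percentage points higher from compound 2 to compound 3 (beyond the scatter) is the single measured change in one place and it lies beyond the scatter.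

Compound 4 `CC(C)(C)ONC(=N)c1ccc2[nH]c(-c3cccc(-c4ccccc4O)c3O)cc2c1` has not yet been measured. It differs from compound 3 in one place: a group of 8 heavy atoms (5 carbon, 2 nitrogen, 1 oxygen; no ring) in place of a group of 7 heavy atoms (4 carbon, 2 nitrogen, 1 oxygen; no ring), on an aromatic carbon. The oxygen thus keeps a carbon group on it, as in compound 3, rather than the hydrogen of compound 2. Because the step of a number 85 percentage points higher from compound 2 to compound 3 (beyond the scatter) was large and pointed upward once the hydrogen on the oxygen was replaced, compound 4 is expected to stay in the upper region of this assay, though its value can hardly exceed the top value of compound 3. The expected step of a number 25 percentage points lower from compound 3 to compound 4 (beyond the scatter) is therefore a moderate retreat, estimated and not measured. For compound 4 in this assay the estimate is 75%, expected to fall between 40% and 100%.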

Compound 4, oral bioavailability: 38%
Compound 4: the middle estimate sits 37 percentage points above what was measured, outside the stated range (below it).
By their numbers in this assay, from the lowest: compound 2; then compound 4; then compound 3. At a limit, below all of these: compound 1.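

Among these compounds, at this place on the shared core, an aromatic carbon meta to a fused ring and para to a fused ring, the earlier compounds showed only that putting allyl in place of hydrogen on the oxygen went with a large rise. Compound 4 shows that the size of that rise depends strongly on which carbon group is present, with a number 62 percentage points lower from compound 3 to compound 4 (beyond the scatter) in this assay when the group of 8 heavy atoms replaces the group of 7 heavy atoms. Set against hydrogen on the oxygen, the group of 8 heavy atoms still gives a number 23 percentage points higher from compound 2 to compound 4 (beyond the scatter) in this assay, so both compounds with a carbon group on that oxygen stand above compound 2, though by very different margins, and nothing shown gives a reason for the gap between the two groups.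

On these data alone, it remains open whether the fall follows the one extra carbon or the way the carbons are arranged, a question that a methyl, an ethyl or a straight butyl chain on the same oxygen would address. As far as these compounds go, how a benzyl group or another ring-bearing group on that oxygen would behave on this scale also stays open.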